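Working notes: from compound 3 to compound 4

This account rests on a few compounds, and the source may have more. Where it says the series, first, only, none or still open, it means among the compounds named here.

Three compounds share one core and differ in the substituted phenyl group on an aromatic nitrogen. Compound 1 `CC1(C)[C@H]2CC[C@]1(C)N(Cc1cn(-c3cccc(Cl)c3)nn1)C(=O)C2` gives 260 nM in a functional assay on PANC-1 cells (Homo sapiens) for inhibition, read by MTT assay, with a stated time of 24 h; a higher number here means a weaker inhibitor, a lower number a stronger inhibitor. Compound 2 `Cc1ccccc1-n1cc(CN2C(=O)C[C@@H]3CC[C@@]2(C)C3(C)C)nn1` gives 250 nM, and compound 3 `COc1ccccc1-n1cc(CN2C(=O)C[C@@H]3CC[C@@]2(C)C3(C)C)nn1` gives 120 nM, the lowest of the three numbers. Going by the values given here, the step of a 1.0-fold lower number from compound 1 to compound 2 (0.02 log units; within the scatter) stays within the scatter, whereas a 2.2-fold lower number from compound 1 to compound 3 (0.34 log units; beyond the scatter) and a 2.1-fold lower number from compound 2 to compound 3 (0.32 log units; beyond the scatter) are both modest and beyond it, so compound 3 stands apart from the other two on the numbers so far.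

Compound 4 `COc1ccc(-n2cc(CN3C(=O)C[C@@H]4CC[C@@]3(C)C4(C)C)nn2)cc1` holds the same atoms as compound 3, joined differently: 4-methoxyphenyl in place of 2-methoxyphenyl on an aromatic nitrogen. Among the compounds with values here, no measured step tests where the methoxy sits on the phenyl ring; the comparisons so far exchange one substituent for another and range from within the scatter to modest. Within the data shown here, with no direct precedent, the expected step of a 1.7-fold higher number from compound 3 to compound 4 (0.22 log units; within the scatter) in this assay is small, possibly toward a weaker inhibitor, and may well fall within the scatter. Compound 4 is therefore estimated at 200 nM, with a range from 80 nM to 500 nM.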

Compound 4, half-maximal inhibitory concentration: 330 nM
Beside the measured number, compound 4's estimate is 1.7-fold (0.22 log units) below it, and the stated range covers the measured number.
By their numbers in this assay, from the lowest: compound 3; then compounds 2, 1 and 4 (each within the scatter of the next).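

In this assay, the position of the methoxy on the phenyl ring matters on its own, since a 2.8-fold higher number from compound 3 to compound 4 (0.44 log units; beyond the scatter) comes from moving that one group with no change in atoms, and this step is modest but beyond the scatter. The methoxy alone therefore does not set compound 3 apart: a 1.3-fold higher number from compound 2 to compound 4 (0.12 log units; within the scatter) and a 1.3-fold higher number from compound 1 to compound 4 (0.10 log units; within the scatter) both stay within the scatter, so the 4-methoxyphenyl group of compound 4 shows no separation from the 2-methylphenyl and 3-chlorophenyl groups. No measurement here bears on why the two methoxy placements differ.

Open, on these data alone, is whether the lower number of compound 3 is specific to methoxy or extends to a larger ether such as ethoxy on the same carbon. Also open, as far as these compounds go, is how an amine or a carboxylic acid on the phenyl ring would behave.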